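Para-Nitro Replaces Meta-Chloro on the Piperazine Aryl Ring

A few compounds are considered here, and "the series" means these few. Any claim that something is new, unique, unknown or untested is made for them only; others in the source may bear on it.

Compound 1 `O=C(CN1CCN(c2ccccc2)CC1)N(c1ccccc1)c1ccccc1`: 20.5 mg/kg
Compound 2 `Cc1ccc(N2CCN(CC(=O)N(c3ccccc3)c3ccccc3)CC2)cc1`: > 20 mg/kg
Compound 3 `O=C(CN1CCN(c2cccc(Cl)c2)CC1)N(c1ccccc1)c1ccccc1`: 16.5 mg/kg

All three share a core in which a diphenylamide is joined through a methylene to a piperazine carrying an aryl group. In a functional assay on the whole organism (strain Swiss albino) for inhibition, with Mus musculus as the target, with stated times of 10 min, 5 min and 20 min (on this read-out higher numbers stand for an effect only at larger amounts of compound and lower numbers for an effect already at smaller amounts), compound 1 gives 20.5 mg/kg. The value of compound 2 in this assay, > 20 mg/kg, is a limit of the assay, not a number. Compound 3 gives 16.5 mg/kg in this assay, and it stands beside compound 1, since the step of a 1.2-fold lower number from compound 1 to compound 3 (0.09 log units; within the scatter) lies within the scatter. The step that the limit leaves unreadable from compound 1 to compound 2 cannot be read because of the limit of > 20 mg/kg in this assay, at which 1 of the 3 values shown sits, and an at least 1.2-fold lower number from compound 2 to compound 3 (0.08 log units; that floor lies within the scatter) gives only a floor.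

Compound 4 `O=C(CN1CCN(c2ccc([N+](=O)[O-])cc2)CC1)N(c1ccccc1)c1ccccc1` differs from compound 3 by 4-nitrophenyl in place of 3-chlorophenyl on an amine nitrogen in a ring. The measured steps that touch the aryl ring are small or unreadable, so no step beyond the scatter is expected in this assay. Compound 4 is therefore estimated at 22 mg/kg, between 12 mg/kg and 45 mg/kg. The expected step of a 1.3-fold higher number from compound 3 to compound 4 (0.12 log units; within the scatter) is small, with a real chance that only a limit is reported.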

Compound 4, dose for half-maximal effect: 30 mg/kg
Beside the measured number, compound 4's estimate is 1.4-fold (0.13 log units) below it; low and high end bracket the measured number.
By their numbers in this assay, from the lowest: compounds 3, 1 and 4 (each within the scatter of the next).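

Read in this assay, the steps of a 1.8-fold higher number from compound 3 to compound 4 (0.26 log units; within the scatter) and a 1.5-fold higher number from compound 1 to compound 4 (0.17 log units; within the scatter) show that the aryl ring on the amine nitrogen in the ring can carry 4-nitrophenyl, with its 2 hydrogen-bond acceptors, without a step beyond the scatter. With compound 4, a nitro group gives a readable number where the methyl group of 4-methylphenyl gave none. The step from compound 2 to compound 4 cannot be read, and the reason lies in the value of compound 2: the limit of > 20 mg/kg in this assay, at which 1 of the 4 values shown sits.

The step from compound 3 to compound 4 changes both the group and its place on the ring, so the compounds shown do not separate the two. As far as these compounds go, it also remains open whether an amine or a carboxylic acid on this ring would give a step beyond the scatter.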